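The source may report more compounds than this note shows. Statements on the series, on what has been measured and on what is new or still open speak of the compounds shown alone.

Three compounds have been measured in a functional assay for inhibition of sodium/hydrogen exchanger (Oryctolagus cuniculus); on this read-out lower numbers stand for stronger inhibition and higher numbers for weaker inhibition:

Compound 1, `Cc1cc(F)c(S(C)(=O)=O)cc1C(=O)N=C(N)N`, gives 44 nM.
Compound 2, `Cc1cc(C2CCCCC2)c(S(C)(=O)=O)cc1C(=O)N=C(N)N`, gives 22 nM.
Compound 3, `Cc1cc(OC2CCCCC2)c(S(C)(=O)=O)cc1C(=O)N=C(N)N`, gives 37 nM.

On these numbers compound 3 stands second highest of the three, but its neighbours are close on either side: a 1.2-fold lower number from compound 1 to compound 3 (0.08 log units; within the scatter), and a 1.7-fold higher number from compound 2 to compound 3 (0.23 log units; within the scatter), so all three sit together within the usual scatter and none can be called the stronger inhibitor.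

Compound 4, `Cc1cc(Oc2ccccc2Cl)c(S(C)(=O)=O)cc1C(=O)N=C(N)N`, has not been measured. It differs from compound 3 in one place: 2-chlorophenyl in place of cyclohexyl on an oxygen on an aromatic ring. Among the measured compounds shown here, two measured steps touch the same position. The replacement of fluoro by cyclohexyloxy (a 1.2-fold lower number from compound 1 to compound 3 (0.08 log units; within the scatter)) and the replacement of cyclohexyl by cyclohexyloxy (a 1.7-fold higher number from compound 2 to compound 3 (0.23 log units; within the scatter)) both stayed within the scatter, which suggests this position tolerates quite different groups without a large shift. For the measured compounds named here, no measured pair, however, exchanges a saturated ring for an aromatic one on the oxygen, so that part of the change is untested. The expectation for this assay is therefore a step of a 1.1-fold lower number from compound 3 to compound 4 (0.02 log units; within the scatter), with no strong reason to expect a move beyond the scatter in either direction. On that basis compound 4 is estimated at 35 nM, within a range of 12 nM to 110 nM.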

Compound 4, half-maximal inhibitory concentration: 14 nM
Estimate against measurement, compound 4: 2.5-fold (0.40 log units) above; the range from low to high includes it.
By their numbers in this assay, from the lowest: compounds 4, 2, 3 and 1 (each within the scatter of the next, the first and the last beyond it).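

In this assay, among the compounds shown here, exchanging the saturated ring on the oxygen for an aromatic one produces a modest step that clears the scatter (a 2.6-fold lower number from compound 3 to compound 4 (0.42 log units; beyond the scatter)), so the group carried by this oxygen can matter, which the earlier compounds could not show. For the compounds shown here, the 2-chlorophenoxy group also separates from fluoro (a 3.1-fold lower number from compound 1 to compound 4 (0.50 log units; beyond the scatter)), whereas cyclohexyloxy did not, and this is the first sign that the position responds to what is placed there, although the step from directly attached cyclohexyl (a 1.6-fold lower number from compound 2 to compound 4 (0.20 log units; within the scatter)) stays within the scatter, so those two groups cannot be told apart on these numbers. Nothing available here explains why the change has this effect.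

The compounds shown leave open whether the step belongs to the aromatic ring itself or to its chlorine, a question that an unsubstituted phenyl on the oxygen could help to separate. They also leave open how the position would respond to an amine or a carboxylic acid, as all the groups shown here carry no net charge.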